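The source may report more compounds than this note shows. Statements on the series, on what has been measured and on what is new or still open speak of the compounds shown alone.

Compounds 1, 2 and 3 share one core and differ only in the group carried on a double-bonded chain carbon bound to a double-bonded chain carbon. Compound 1 is `COc1cc(OC)c(OC)cc1/C=C/COC(=O)/C=C/c1ccc(OC)c(OC)c1`, compound 2 is `COc1cc(OC)c(OC)cc1/C=C/COC(=O)/C=C/c1ccc(Br)cc1` and compound 3 is `COc1cc(OC)c(OC)cc1/C=C/COC(=O)/C=C/c1cccc(Br)c1`. In a functional assay on the whole organism (strain Kunming) with Mus musculus as the target, with a stated time of 0.5 h, at a dose of 300 mg/kg by the intraperitoneal route (a higher number here means a weaker effect of the compound at the dose given, a lower number a stronger effect), compound 1 gives 100%, compound 2 gives 100% and compound 3 gives 100%. Compound 3 thus stands level with the other two: the step of no change at the digits printed from compound 1 to compound 3 (within the scatter) and the step of no change at the digits printed from compound 2 to compound 3 (within the scatter) show nothing beyond the scatter, and the same holds for no change at the digits printed from compound 1 to compound 2 (within the scatter).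

Compound 4 is `COc1ccc(/C=C/C(=O)OC/C=C/c2cc(OC)c(OC)cc2OC)cc1`. The change from compound 3 to compound 4 is 4-methoxyphenyl in place of 3-bromophenyl on a double-bonded chain carbon bound to a double-bonded chain carbon. Going by the values given here, the steps that bear on this are no change at the digits printed from compound 1 to compound 3 (within the scatter), no change at the digits printed from compound 2 to compound 3 (within the scatter) and no change at the digits printed from compound 1 to compound 2 (within the scatter), each without a change beyond the scatter. With three different groups at that place all giving the same reading, no step beyond the scatter is expected in this assay, so no change at the digits printed from compound 3 to compound 4 (within the scatter) is the step expected. Compound 4 is therefore estimated at 100%, with a range from 85% to 100%.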

Compound 4, a percentage reported as activity, at one dose (the size of the read-out at that dose, not a potency): 100%
Compound 4: middle estimate and measured number agree at the digits printed; the measured number falls inside the stated range.
By their numbers in this assay, from the lowest: compounds 1, 2, 3 and 4 (each within the scatter of the next).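

In this assay, 4-methoxyphenyl in place of 3-bromophenyl gives no change at the digits printed from compound 3 to compound 4 (within the scatter) and extends the flat reading at this place to a fourth group. Two smaller changes on the aromatic ring can now be read alone: methoxy in place of bromo gives no change at the digits printed from compound 2 to compound 4 (within the scatter) and hydrogen in place of methoxy gives no change at the digits printed from compound 1 to compound 4 (within the scatter) in this comparison. Neither change moves the reading, and nothing available explains this flat result.

All four compounds give the same reading, so they do not show whether any group at this place can lower the number at all. An amine or a carboxylic acid on the aromatic ring, or a longer chain in place of that ring, would test this, as would changes elsewhere in the shared core.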